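The source may report more compounds than this note shows. Statements on the series, on what has been measured and on what is new or still open speak of the compounds shown alone.

Of the compounds shown here, two sharing one core have been measured in an assay on FRT cells for positive allosteric modulation of Cystic fibrosis transmembrane conductance regulator variant N1303K (Homo sapiens), in the presence of a further agent that is not named here; a lower number here means that less compound is needed, a higher number that more compound is needed for the effect. Compound 1 `COc1ccc2[nH]c3c(c2c1)CCNC31CCN(Cc2ccc([N+](=O)[O-])cc2F)CC1` gives 5900 nM in this assay, and compound 2 `COc1ccc2[nH]c3c(c2c1)CCNC31CCN(Cc2ccc(F)c(Cl)c2F)CC1` gives 4500 nM. Within the data shown here, the step of a 1.3-fold lower number from compound 1 to compound 2 (0.12 log units; within the scatter) replaces the whole substitution pattern of the benzyl ring and stays within the scatter, so compound 2 stands at the smaller of the two numbers only nominally, with compound 1 as its sole neighbour. Compound 3 `COc1ccc2[nH]c3c(c2c1)CCNC31CCN(Cc2ccc(F)cc2F)CC1` differs from compound 2 by hydrogen in place of chloro on an aromatic carbon. Among the measured compounds shown here, only one measured step concerns this ring, a 1.3-fold lower number from compound 1 to compound 2 (0.12 log units; within the scatter), and it changed several groups at once without leaving the scatter; no measured step removes a single chloro. Compound 3 is therefore expected to show a small step, if any, a 1.4-fold higher number from compound 2 to compound 3 (0.16 log units; within the scatter), toward a somewhat larger number. The estimate for compound 3 is 6500 nM, with a range from 2500 nM to 16000 nM.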

Compound 3, half-maximal effective concentration: 2000 nM
Estimate against measurement, compound 3: 3.3-fold (0.51 log units) above; measured number below the stated range.
By their numbers in this assay, from the lowest: compound 3; then compounds 2 and 1 (each within the scatter of the next).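

In this assay, among these compounds, hydrogen in place of chloro on the aromatic carbon ortho to two fluoro groups gives a 2.3-fold lower number from compound 2 to compound 3 (0.35 log units; beyond the scatter), the first step on this ring that lies beyond the scatter, so the chloro at this carbon is not neutral for the measured number. Fluoro in place of nitro gives a 3.0-fold lower number from compound 1 to compound 3 (0.47 log units; beyond the scatter), so the 2,4-difluorobenzyl group stands apart from both other benzyl groups, although those two remain within the scatter of each other. No measurement offered here accounts for either step.

On these data alone, whether a methyl or methoxy group on that same carbon would fall with hydrogen or with chloro stays open. Also open, as far as these compounds go, is how the number responds when either fluoro of compound 3 is replaced by hydrogen or by an amine.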